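Piperazine chain length versus plain alkyl in a dicyanopyrazine series

This account rests on a few compounds, and the source may have more. Where it says the series, first, only, none or still open, it means among the compounds named here.

Measured so far in a functional assay on Raji cells (Homo sapiens) for antiproliferative activity, read by MTT assay, with a stated time of 48 h; on this read-out lower numbers stand for stronger inhibition and higher numbers for weaker inhibition:
compound 1 `CN1CCN(CCn2c(N)c(-c3nc4ccccc4[nH]3)c3nc(C#N)c(C#N)nc32)CC1` gives > 50000 nM, which is a limit of the assay.
compound 2 `CCCn1c(N)c(-c2nc3ccccc3[nH]2)c2nc(C#N)c(C#N)nc21` gives > 50000 nM, which is a limit of the assay.
compound 3 `CN1CCN(CCCn2c(N)c(-c3nc4ccccc4[nH]3)c3nc(C#N)c(C#N)nc32)CC1` gives 2620 nM.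

Among the measured compounds shown here, compound 3 thus supplies the only number; the other two values sit at the limit of > 50000 nM in this assay, at which 2 of the 3 values shown sit. The cores of compound 1 and compound 3 differ by (4-methylpiperazin-1-yl)methyl in place of 4-methylpiperazin-1-yl on a saturated chain carbon, two bonds along the chain from an aromatic nitrogen, and that difference carries an at least 19-fold lower number from compound 1 to compound 3 (1.28 log units; beyond the scatter). Likewise an at least 19-fold lower number from compound 2 to compound 3 (1.28 log units; beyond the scatter) is large. The change methyl in place of 4-methylpiperazin-1-yl on a saturated chain carbon, two bonds along the chain from an aromatic nitrogen gives a step that the two limits leave unreadable from compound 1 to compound 2, since both ends rest at the limit of > 50000 nM in this assay, at which 2 of the 3 values shown sit.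

Compound 4 `CCCCn1c(N)c(-c2nc3ccccc3[nH]2)c2nc(C#N)c(C#N)nc21` is not yet measured. It differs from compound 3 by methyl in place of 4-methylpiperazin-1-yl on a saturated chain carbon, three bonds along the chain from an aromatic nitrogen. This is the same kind of change as from compound 1 to compound 2, but not the same: there the place is on a saturated chain carbon two bonds along the chain from an aromatic nitrogen, here it is three bonds along the chain from an aromatic nitrogen. The earlier step is unreadable, so it gives no size to carry over.

The expectation rests on compound 2, which gives > 50000 nM, a limit of the assay. With the 4-methylpiperazin-1-yl removed, compound 4 is expected to fall back toward that limit, so the step from compound 3 is estimated at a 19-fold higher number from compound 3 to compound 4 (1.28 log units; beyond the scatter). Compound 4 is estimated at 50000 nM, with a range from 12000 nM to 150000 nM, and most likely the assay again reports only a limit.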

Compound 4, half-maximal inhibitory concentration: > 50000 nM
Compound 4 ended at the assay's limit; the forecaster's own chance of this, stated with the estimate: 75%; the middle value sits exactly at the limit.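

In this assay, methyl in place of 4-methylpiperazin-1-yl on a saturated chain carbon, three bonds along the chain from an aromatic nitrogen, carries an at least 19-fold higher number from compound 3 to compound 4 (1.28 log units; beyond the scatter), which is a bound on the size of the step and not a measured size. The same kind of change two bonds along the chain, from compound 1 to compound 2, cannot be read, and neither can the other pairs that end at a limit on both sides: the limit of > 50000 nM in this assay, at which 3 of the 4 values shown sit. The 4-methylpiperazin-1-yl group is thus tied to a readable value only as 3-(4-methylpiperazin-1-yl)propyl in compound 3, compound 1 with 2-(4-methylpiperazin-1-yl)ethyl goes against any rule that the group alone is enough, and since all four compounds share one core, nothing here tests the change on another core.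

The compounds shown leave open whether a longer chain carrying the same 4-methylpiperazin-1-yl group lowers the number further than in compound 3. They also leave open whether the ring itself matters, or whether a simpler amine such as dimethylamino, or a morpholine, on the same propyl chain would serve as well.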